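Working notes on cytotoxicity across four related compounds

The source may hold more compounds than are shown below. What is called first, only, known or untested is meant among the compounds shown, and "the series" means these compounds.

Measured so far:
Compound 1 `C/C(=N\NC(N)=O)c1ccc2[nH]c(-c3ccccc3)nc2c1` gives > 100000 nM in an ADME assay on MDBK cells (Bos taurus) for cytotoxicity, read by MTT assay, with a stated time of 96 h; on this read-out lower numbers stand for higher toxicity in this test and higher numbers for lower toxicity in this test; this is a limit of the assay, not a number.
Compound 2 `C/C(=N\NC(N)=O)c1ccc2c(c1)nc(-c1ccccc1)n2C1CCCCC1` gives > 100000 nM in this assay; again a limit.
Compound 3 `C/C(=N\NC(N)=O)c1ccc2c(c1)nc(-c1ccoc1)n2C1CCCCC1` gives > 100000 nM in this assay; again a limit.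

Two changes connect them. From compound 2 to compound 1 the change is hydrogen in place of cyclohexyl on an aromatic nitrogen, and the step that the two limits leave unreadable from compound 2 to compound 1 is not readable; both ends are limits. From compound 2 to compound 3 the cores differ by furan-3-yl in place of phenyl on an aromatic carbon, and here too the step that the two limits leave unreadable from compound 2 to compound 3 is not readable. All three values sit at the limit of > 100000 nM in this assay, at which 3 of the 3 values shown sit.

Compound 4 `C/C(=N\NC(N)=O)c1ccc2[nH]c(-c3ccoc3)nc2c1` is not yet measured. It differs from compound 3 by hydrogen in place of cyclohexyl on an aromatic nitrogen. Among the compounds with values here, this is the same kind of change as the one from compound 2 to compound 1, though the place differs: there the ring nitrogen sits next to the ring atom that bears a phenyl group, here next to the ring atom that bears a furan-3-yl group. Beside the earlier step that the two limits leave unreadable from compound 2 to compound 1, the expected step that the limit leaves unreadable from compound 3 to compound 4 in this assay is taken as small, which rests on compound 3 standing at the limit of > 100000 nM in this assay, at which 3 of the 3 values shown sit, together with every other compound. Compound 4 is expected to give about 150000 nM, between 60000 nM and 400000 nM, and most likely to be reported only as a limit.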

Compound 4, half-maximal cytotoxic concentration: > 100000 nM
Compound 4 was reported as a limit; the forecaster's own chance of this, stated with the estimate: 85%; the middle value is on the limit's open side.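

No new step can be read between compound 3 and compound 4 or between compound 1 and compound 4, because both ends of each pair are limits of the assay and not numbers: the limit of > 100000 nM in this assay, at which 4 of the 4 values shown sit.

The compounds shown leave open how the four compare in this assay, and whether replacing cyclohexyl with hydrogen or phenyl with furan-3-yl changes cytotoxicity at all.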